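A few compounds are considered here, and "the series" means these few. Any claim that something is new, unique, unknown or untested is made for them only; others in the source may bear on it.

In a functional assay on CHO cells for positive allosteric modulation of metabotropic glutamate receptor 2 (Homo sapiens), with a stated time of 30 min; on this read-out higher numbers stand for an effect only at larger amounts of compound and lower numbers for an effect already at smaller amounts:
- compound 1 `CC(C)CCn1ccc(CCc2ccccc2)c(C#N)c1=O` gives 361 nM
- compound 2 `N#Cc1c(N2CCC(c3ccccc3F)CC2)ccn(CC2CC2)c1=O` gives 81 nM

Of the two numbers, compound 2 holds the lower one; compound 1 stands higher, beyond the scatter. Compound 3 `N#Cc1c(N2CCC(c3c(F)cccc3F)CC2)ccn(CC2CC2)c1=O` differs from compound 2 by fluoro in place of hydrogen on an aromatic carbon. For the measured compounds named here, no step of this kind has been measured, so nothing measured tells its size. In this assay a small step is expected, if any, toward a lower number, and not clearly beyond the scatter. For compound 3 the estimate is 60 nM, with a range from 20 nM to 200 nM, which amounts to an expected step of a 1.4-fold lower number from compound 2 to compound 3 (0.13 log units; within the scatter).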

Compound 3, half-maximal effective concentration: 31 nM
Beside the measured number, compound 3's estimate is 1.9-fold (0.29 log units) above it; the range from low to high includes it.
By their numbers in this assay, from the lowest: compound 3; then compound 2; then compound 1.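

In this assay, for the compounds shown here, the change from 2-fluorophenyl to 2,6-difluorophenyl gives a 2.6-fold lower number from compound 2 to compound 3 (0.42 log units; beyond the scatter), the first single-place step, and it is modest but beyond the scatter. A second fluoro on this aromatic carbon, ortho to a large group, is therefore tolerated and moves the number lower in this one pair. Nothing at hand explains the size of this step. As far as these compounds go, it remains open whether chloro, methoxy or trifluoromethyl at this place would move the number the same way. Also open, from the compounds shown here alone, is whether the step holds with a longer chain in place of the cyclopropylmethyl group.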